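A few compounds are considered here, and "the series" means these few. Any claim that something is new, unique, unknown or untested is made for them only; others in the source may bear on it.

Measured compounds in the series:
compound 1, `CN(C(=O)NC(=O)c1ccc(F)c(F)c1)c1nc(C(F)(F)F)c(C(=O)N/N=C/c2ccccc2C(F)(F)F)s1`, 8.21 ug/mL
compound 2, `CN(C(=O)NC(=O)c1ccc(Cl)cc1Cl)c1nc(C(F)(F)F)c(C(=O)N/N=C/c2ccccc2C(F)(F)F)s1`, 9.12 ug/mL

Both numbers come from a functional assay on MCF7 cells (Homo sapiens) for inhibition, read by MTT assay, with a stated time of 72 h; on this read-out higher numbers stand for weaker inhibition and lower numbers for stronger inhibition. Compound 2 stands highest of the two numbers shown, with compound 1 nearest; the step from one to the other, a 1.1-fold higher number from compound 1 to compound 2 (0.05 log units; within the scatter), lies within the scatter, so no order between compound 1 and compound 2 can be read from these values.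

Compound 3, `CN(C(=O)NC(=O)c1c(Cl)cccc1Cl)c1nc(C(F)(F)F)c(C(=O)N/N=C/c2ccccc2C(F)(F)F)s1`, has not yet been measured in this assay. It differs from compound 2 by 2,6-dichlorophenyl in place of 2,4-dichlorophenyl on a carbonyl carbon. For the measured compounds named here, the one measured step that bears on this change is the exchange of aryl groups on the same carbonyl carbon, a 1.1-fold higher number from compound 1 to compound 2 (0.05 log units; within the scatter), which stayed within the scatter. On that basis a further exchange of the aryl group at this carbonyl carbon is expected to leave the number about where compound 2 sits, with no step beyond the scatter in either direction, that is a 1.0-fold lower number from compound 2 to compound 3 (0.01 log units; within the scatter). Compound 3 is therefore estimated at 9 ug/mL in this assay, within a range of 4.5 ug/mL to 18 ug/mL.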

Compound 3, half-maximal inhibitory concentration: 6.24 ug/mL
Beside the measured number, compound 3's estimate is 1.4-fold (0.16 log units) above it; measured number inside the range.
By their numbers in this assay, from the lowest: compounds 3, 1 and 2 (each within the scatter of the next).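

In this assay, 2,6-dichlorophenyl in place of 2,4-dichlorophenyl on the carbonyl carbon gives a 1.5-fold lower number from compound 2 to compound 3 (0.16 log units; within the scatter); these two groups have the same atoms, joined differently, so this pair tests the arrangement of the two chlorines alone, and that change does not separate from the scatter. 3,4-Difluorophenyl and 2,6-dichlorophenyl at the same place give a 1.3-fold lower number from compound 1 to compound 3 (0.12 log units; within the scatter), so all three aryl groups now shown on this carbonyl carbon, which carry fluorine or chlorine in different arrangements, remain within the scatter of one another, with no compound among the three going against that reading. Nothing available bears on the reason for these values or on what this flat set of numbers reflects.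

As far as these compounds go, whether this position tolerates any larger departure stays open, as all three compounds carry a dihalophenyl group there, and an unsubstituted phenyl, a methoxyphenyl, a cyclohexyl or an aminophenyl group would test a wider range. The rest of the structure is identical across the compounds shown, so the effect of replacing the trifluoromethyl on the thiazole-side core or on the benzylidene end with, for example, a carboxylic acid or an amine also remains open.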